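A few compounds are considered here, and "the series" means these few. Any claim that something is new, unique, unknown or untested is made for them only; others in the source may bear on it.

Compound 1 `O=C(Nc1cccc(-c2oc3cc(-c4ccc(F)cc4)ccc3c(=O)c2O)c1)c1ccccc1F` is the starting point of this short series. In a functional assay on MDA-MB-231 cells (Homo sapiens) for antiproliferative activity, read by CCK-8 assay, with a stated time of 72 h (on this read-out higher numbers stand for weaker inhibition and lower numbers for stronger inhibition), compound 1 gives 7240 nM. Compound 2 `Cc1cc(C)cc(C(=O)Nc2cccc(-c3oc4cc(-c5ccc(F)cc5)ccc4c(=O)c3O)c2)c1` keeps the whole shared core and differs only in the ring attached to the amide carbonyl; in this assay compound 2 gives 11900 nM. Among the measured compounds shown here, the one step that connects them, a 1.6-fold higher number from compound 1 to compound 2 (0.22 log units; within the scatter), shows that exchanging one six-membered aromatic ring on the carbonyl carbon for another left the read-out essentially where it was, so compound 2 and compound 1 sit within the scatter of each other and neither can be called the stronger inhibitor.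

Compound 3 `O=C(Nc1cccc(-c2oc3cc(-c4ccc(F)cc4)ccc3c(=O)c2O)c1)c1ccc(-c2ccccc2)cc1` is not yet measured. It differs from compound 2 in the same position: 4-phenylphenyl in place of 3,5-dimethylphenyl on a carbonyl carbon. For the measured compounds named here, the only measured step that bears on this kind of change is the one from compound 1 to compound 2, and that step stayed within the scatter. On that basis no step beyond the scatter is expected in this assay, and the expected change is a 1.2-fold lower number from compound 2 to compound 3 (0.08 log units; within the scatter). Compound 3 is therefore estimated at 10000 nM, within a range from 3000 nM to 35000 nM.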

Compound 3, half-maximal inhibitory concentration: 63200 nM
Compound 3: middle estimate off by 6.3-fold (0.80 log units), on the low side; the whole stated range lies below it.
By their numbers in this assay, from the lowest: compounds 1 and 2 (each within the scatter of the next); then compound 3.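

The earlier step, a 1.6-fold higher number from compound 1 to compound 2 (0.22 log units; within the scatter), suggested that the ring on the amide carbonyl carbon could change with little effect, but this position does respond to the group placed there. Placing 4-phenylphenyl on that carbonyl carbon gives a 5.3-fold higher number from compound 2 to compound 3 (0.73 log units; beyond the scatter) in this assay and also an 8.7-fold higher number from compound 1 to compound 3 (0.94 log units; beyond the scatter) as the second step beyond the scatter, so among these three compounds the group with 2 six-membered aromatic rings goes with the weakest inhibition, while 2-fluorophenyl and 3,5-dimethylphenyl cannot be separated from each other. Nothing available here explains why this change weakens inhibition.

The compounds shown leave open whether the loss follows from the second aromatic ring itself or from how far the group reaches from the carbonyl carbon, a question that a benzyl group or a longer chain ending in a phenyl ring could help to address. They also leave open how this position would respond to a group of a different kind, such as an amine or a carboxylic acid on the ring.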